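Replacing the propargyl group of compound 3 with 4-ethoxyphenyl

The compounds below may be only part of what the source reports. "The series", "measured", "known", "first", "only" and "open" are said of these compounds alone.

Three compounds of a shared core have numbers in an assay on HL-60 cells for agonist activity at vitamin D3 receptor (Homo sapiens), read by microscopy, with a stated time of 96 h; on this read-out higher numbers stand for an effect only at larger amounts of compound and lower numbers for an effect already at smaller amounts: compound 1 `C#CCNC(=O)c1ccc(C(CC)(CC)c2ccc(OCC(=O)C(C)(C)C)c(C)c2)n1CC` gives 2200 nM, compound 2 `C=CCN(C)C(=O)c1ccc(C(CC)(CC)c2ccc(OCC(=O)C(C)(C)C)c(C)c2)n1CC` gives 21600 nM, and compound 3 `C#CCNC(=O)c1ccc(C(CC)(CC)c2ccc(OCC(O)C(C)(C)C)c(C)c2)n1CC` gives 240 nM. Compound 3 has the lowest of the three numbers; it is separated from compound 1 by a 9.2-fold lower number from compound 1 to compound 3 (0.96 log units; beyond the scatter), and from compound 2 by a much wider gap. Compound 4 `CCOc1ccc(NC(=O)c2ccc(C(CC)(CC)c3ccc(OCC(O)C(C)(C)C)c(C)c3)n2CC)cc1` differs from compound 3 in one place: 4-ethoxyphenyl in place of propargyl on an amide-type nitrogen. For the measured compounds named here, no measured step matches this change. Going by the values given here, the one step that touches the same amide-type nitrogen is a 9.8-fold higher number from compound 1 to compound 2 (0.99 log units; beyond the scatter), a change from propargylamino to allyl(methyl)amino that worsened the number. The step of a 9.2-fold lower number from compound 1 to compound 3 (0.96 log units; beyond the scatter) lies at a different place and does not speak to the amide. Given that the only related step worsened the number and that a much larger group now enters, compound 4 is expected to show a modest rise, a 2.5-fold higher number from compound 3 to compound 4 (0.40 log units; beyond the scatter), with wide uncertainty. The estimate for compound 4 in this assay is 600 nM, within a range from 120 nM to 4000 nM.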

Compound 4, half-maximal effective concentration: 630 nM
For compound 4 the middle estimate is 1.1-fold (0.02 log units) below the measured one; low and high end bracket the measured number.
By their numbers in this assay, from the lowest: compound 3; then compound 4; then compound 1; then compound 2.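

At the amide-type nitrogen, the propargyl group of three heavy atoms gave way to a 4-ethoxyphenyl group of nine, bringing in a six-membered aromatic ring and a hydrogen-bond acceptor, and in this assay this produced a 2.6-fold higher number from compound 3 to compound 4 (0.42 log units; beyond the scatter), a rise beyond the scatter. That rise is smaller than the earlier change on the same nitrogen, a 9.8-fold higher number from compound 1 to compound 2 (0.99 log units; beyond the scatter), which also removed the amide hydrogen that compound 4 retains, so this position accepts an aromatic ring at a modest cost in this series. No supporting evidence bears on why the number rose.

On these data alone, it remains open whether the rise follows from the ring itself or from its ethoxy group, which plain phenyl or 4-methoxyphenyl on the same nitrogen would address. A saturated ring such as cyclohexyl would test whether the aromatic character of the ring matters at this position.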